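This account rests on a few compounds, and the source may have more. Where it says the series, first, only, none or still open, it means among the compounds named here.

Compound 1 `CC(=O)c1ccc(NC(=O)Nc2cc(C)nc3ccccc23)cc1`: in an ADME assay on HepG2 cells (Homo sapiens) for cytotoxicity, with a stated time of 72 h (on this read-out lower numbers stand for an effect already at smaller amounts and higher numbers for an effect only at larger amounts of compound), compound 1 gives 19000 nM.
Compound 2 `Cc1cc(NC(=O)Nc2ccc(N(C)C)cc2)c2ccccc2n1`: in this assay compound 2 gives only a limit of the assay, > 25000 nM.

Compound 2 thus stands at a limit, not a number, in this assay (the limit of > 25000 nM in this assay, at which 1 of the 2 values shown sits). Compound 3 `Cc1cc(NC(=O)Nc2ccc(N)cc2)c2ccccc2n1` differs from compound 2 by amino in place of dimethylamino on an aromatic carbon. Within the data shown here, no measured step swaps these two groups; the only measured step, an at least 1.3-fold higher number from compound 1 to compound 2 (0.11 log units; that floor lies within the scatter), gives no firm size. In this assay the expected step of a number no higher from compound 2 to compound 3 (the limit leaves the size open) is therefore none beyond the scatter. Compound 3 is expected at 25000 nM, with a range from 12000 nM to 50000 nM.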

Compound 3, half-maximal effective concentration: > 25000 nM
Compound 3 ended at the assay's limit; the forecaster's own chance of this, stated with the estimate: 60%; the middle value sits exactly at the limit.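

In this assay, compound 3 also ends at a limit and not at a number, so amino, like dimethylamino, gives no readable value at this place. Compared with acetyl, amino gives an at least 1.3-fold higher number from compound 1 to compound 3 (0.11 log units; that floor lies within the scatter), so no firm size can be stated for this change either. The step between compound 2 and compound 3 cannot be read because both values are limits: the limit of > 25000 nM in this assay, at which 2 of the 3 values shown sit.

Going by these compounds, how far past the limit compound 2 and compound 3 truly lie stays open. So does whether a carboxylic acid or a longer chain at this place would give a readable number.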